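From cyclopropylmethyl to 1-phenylethyl on the shared core

This account rests on a few compounds, and the source may have more. Where it says the series, first, only, none or still open, it means among the compounds named here.

In a functional assay on A549 cells (Homo sapiens) for inhibition (on this read-out higher numbers stand for weaker inhibition and lower numbers for stronger inhibition), compound 1 `N[C@H]1CC[C@H](Nc2nc(NCc3cccc(I)c3)c3ncn(C4CCCC4)c3n2)CC1` gives 1000 nM and compound 2 `N[C@H]1CC[C@H](Nc2nc(NCC3CC3)c3ncn(C4CCCC4)c3n2)CC1` gives 1600 nM so the two stand within the scatter of each other. Compound 3 `C[C@H](Nc1nc(N[C@H]2CC[C@H](N)CC2)nc2c1ncn2C1CCCC1)c1ccccc1` has 1-phenylethyl in place of cyclopropylmethyl on a nitrogen on an aromatic ring, a change counted as 1-phenylethyl in place of cyclopropylmethyl on a nitrogen on an aromatic ring and not yet measured. Among the compounds with values here, the one measured step bearing on this is a 1.6-fold higher number from compound 1 to compound 2 (0.20 log units; within the scatter) with cyclopropyl in place of 3-iodophenyl on a saturated chain carbon bound to a nitrogen on an aromatic ring. From so small a step, no change beyond the scatter is expected in this assay and the expected step is a 1.2-fold lower number from compound 2 to compound 3 (0.09 log units; within the scatter) in no firm direction. For compound 3 the estimate is 1300 nM within an expected range of 500 nM to 3300 nM on this read-out.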

Compound 3, half-maximal inhibitory concentration: 6100 nM
The estimate for compound 3 lay 4.7-fold (0.67 log units) below the measured number; measured number outside the range, above it.
By their numbers in this assay, from the lowest: compounds 1 and 2 (each within the scatter of the next); then compound 3.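

In this assay, this position on a nitrogen on an aromatic ring does not treat all groups alike: 1-phenylethyl gives a 3.8-fold higher number from compound 2 to compound 3 (0.58 log units; beyond the scatter) and a 6.1-fold higher number from compound 1 to compound 3 (0.79 log units; beyond the scatter), both beyond the scatter. An aromatic ring alone does not settle the number, as 3-iodobenzyl and 1-phenylethyl both carry one yet end clearly apart. No available evidence explains this rise. The compounds shown leave open whether the gap between compound 1 and compound 3 goes with the iodine or with the defined stereocentre of 1-phenylethyl. A plain benzyl group, with neither feature, would help to separate the two.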